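Bromine moved around the phenoxy ring: compound 2 to 3

The compounds below may be only part of what the source reports. "The series", "measured", "known", "first", "only" and "open" are said of these compounds alone.

Two members of the series have been run in a functional assay on HCT-116 cells (Homo sapiens) for antiproliferative activity, read by MTT assay, with a stated time of 72 h; a lower number here means a stronger inhibitor, a higher number a weaker inhibitor. Compound 1 `NC1=NC2(CCOCC2)N(OCCCOc2cc(Cl)c(Cl)cc2Cl)C(N)=N1` gives 2750 nM. Compound 2 `NC1=NC2(CCOCC2)N(OCCCOc2ccccc2Br)C(N)=N1` gives 30 nM, the lowest of the two numbers, set apart from compound 1 by a 92-fold lower number from compound 1 to compound 2 (1.96 log units; beyond the scatter). Among the measured compounds shown here, that single step is the only comparison recorded so far, and it involves the swap of a 2,4,5-trichlorophenyl for a 2-bromophenyl on an oxygen on a saturated carbon.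

Compound 3 `NC1=NC2(CCOCC2)N(OCCCOc2ccc(Br)cc2)C(N)=N1` is not yet measured. It differs from compound 2 by 4-bromophenyl in place of 2-bromophenyl on an oxygen on a saturated carbon. For the measured compounds named here, no measured pair isolates a shift of a single bromine on the ring, so the step of a 92-fold lower number from compound 1 to compound 2 (1.96 log units; beyond the scatter) bears on it only indirectly: the ring that carried halogens at the 4 and 5 positions as well as the 2 position gave the high number, and the ring with halogen at the 2 position alone gave the low one. On that slender basis a loss of potency is expected, moderate in size, a 5.0-fold higher number from compound 2 to compound 3 (0.70 log units; beyond the scatter), with wide uncertainty. Compound 3 is estimated at 150 nM in this assay, within 40 nM to 600 nM.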

Compound 3, half-maximal inhibitory concentration: 320 nM
The estimate for compound 3 lay 2.1-fold (0.33 log units) below the measured number, within the range that was stated.
By their numbers in this assay, from the lowest: compound 2; then compound 3; then compound 1.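

In this assay, the atoms stay the same and only the bromine moves: going from 2-bromophenyl to 4-bromophenyl on the oxygen gives an 11-fold higher number from compound 2 to compound 3 (1.03 log units; beyond the scatter). The placement of a single bromine on this ring therefore carries a large part of the activity on its own, which the earlier pair could not show, since it changed the halogen, the number of halogens and their placement all at once. A lone bromine as 4-bromophenyl still keeps some ground over 2,4,5-trichlorophenyl, with an 8.6-fold lower number from compound 1 to compound 3 (0.93 log units; beyond the scatter), so the 4-bromophenyl compound sits on the series' scale between the other two rather than matching the high number of compound 1. Nothing measured on these compounds accounts for the shift.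

Open, from the compounds shown here alone, is how a 3-bromophenyl would read, and whether the low number of compound 2 belongs to bromine itself or would hold for a 2-chlorophenyl or a 2-methylphenyl. Also open, going by these compounds, is how an unsubstituted phenyl would compare, and whether the gap between the two bromophenyl compounds survives on a longer chain.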